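The source may hold more compounds than are shown below. What is called first, only, known or untested is meant among the compounds shown, and "the series" means these compounds.

Measured so far:
compound 1 `CCCCN(c1nc2c(CO)cccc2o1)[C@H](C)c1ccc(-c2ccccc2-c2nnn[nH]2)cc1` — 20 ng.h/mL
compound 2 `C[C@H](c1ccc(-c2cc(F)ccc2-c2nc(=O)o[nH]2)cc1)N(CC1CC1)c1nc2c(C(=O)O)cccc2o1` — 4410 ng.h/mL
compound 3 `CCCCN(c1nc2c(C(=O)O)cccc2o1)[C@H](C)c1ccc(-c2ccccc2-c2nnn[nH]2)cc1` — 429 ng.h/mL

In an ADME assay on the whole organism (Macaca fascicularis) for pharmacokinetics, read by LC-MS, using cassette dosing, at a dose of 1 mg/kg by the oral route (on this read-out lower numbers stand for lower exposure and higher numbers for higher exposure at the dose given), compound 1 stands lowest of the three measured numbers. Its nearest neighbour is compound 3, reached by a 21-fold higher number from compound 1 to compound 3 (1.33 log units; beyond the scatter), a step that is beyond the scatter. Among the compounds with values here, compound 2 differs from compound 1 in several places at once, and the two values show only that compound 2 gives the highest number of the set.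

Compound 4 `CCCCN(c1nc2ccccc2o1)[C@H](C)c1ccc(-c2ccccc2-c2nnn[nH]2)cc1` differs from compound 1 by hydrogen in place of hydroxymethyl on an aromatic carbon. Within the data shown here, no measured pair carries this change. Among the measured compounds shown here, the one step at the same position, a 21-fold higher number from compound 1 to compound 3 (1.33 log units; beyond the scatter), brings carboxy in rather than hydrogen, so it shows that this position moves exposure strongly but does not tell in which direction the loss of hydroxymethyl will act. With no direct guide, a step of a 1.8-fold higher number from compound 1 to compound 4 (0.24 log units; within the scatter) is expected, within or close to the scatter. Compound 4 is therefore estimated at 35 ng.h/mL, with a range from 7 ng.h/mL to 180 ng.h/mL.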

Compound 4, area under the concentration-time curve: 44.3 ng.h/mL
Estimate against measurement, compound 4: 1.3-fold (0.10 log units) below, within the range that was stated.
By their numbers in this assay, from the lowest: compound 1; then compound 4; then compound 3; then compound 2.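

With the rest of compound 1 held constant in this assay, hydroxymethyl is not the better of the two groups compared with plain hydrogen on this aromatic carbon: there is a 2.2-fold higher number from compound 1 to compound 4 (0.35 log units; beyond the scatter), a step beyond the scatter. Hydrogen also gives a reference point that carboxy can be read against, with a 9.7-fold lower number from compound 3 to compound 4 (0.99 log units; beyond the scatter), so the three compounds run from hydroxymethyl in compound 1, through hydrogen in compound 4, to carboxy in compound 3, and the large gain from hydroxymethyl to carboxy is only partly the removal of hydroxymethyl. Nothing measured alongside these numbers accounts for this order.

Where an amide or a primary amine on this aromatic carbon would fall against hydrogen and carboxy remains open. From the compounds shown here alone, whether the same order holds with a longer chain in place of the butyl group is also open.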